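Expected Effect of a Larger Ester Group on Binding

This account rests on a few compounds, and the source may have more. Where it says the series, first, only, none or still open, it means among the compounds named here.

Measured compounds:
Compound 1 `CC1=C(C(=O)OCc2ccccc2)C(c2ccco2)NC(=O)N1C`: 11%
Compound 2 `CCOC(=O)C1=C(C)N(C)C(=O)NC1c1cccs1`: 2%

Of the compounds shown here, two share a common core and have been tested in an assay on membranes from HeLa cells for displacement of a labelled ligand from adenosine receptor A3 (Homo sapiens), read by scintillation counting, with a stated time of 180 min, tested at 1 uM; a higher number here means more inhibition at the concentration tested (going by the name of the read-out), a lower number less inhibition. Compound 1 gives 11%, and compound 2 gives 2%. Compound 2 shows the smaller of the two numbers, but its difference to compound 1 lies within the usual scatter, so the two cannot be told apart on these data.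

Compound 3 `CC1=C(C(=O)OC(C)C)C(c2cccs2)NC(=O)N1C` has not yet been measured in this assay. It differs from compound 2 in a single place: methyl in place of hydrogen on a saturated chain carbon bound to an oxygen next to a carbonyl group and a saturated chain carbon. For the measured compounds named here, no pair of measured compounds shows what this kind of change does here, so no measured step can guide the expectation. Both measured numbers are low, and a change of this small size is expected to leave the number close to where compound 2 stands, with no step beyond the scatter. For compound 3 the expected value in this assay is 5%, in a range from -5% to 20%. The expected step is a number 3 percentage points higher from compound 2 to compound 3 (within the scatter).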

Compound 3, a percentage reported as inhibition, at one concentration (the size of the read-out at that concentration, not a potency): 17%
Compound 3: the middle estimate sits 12 percentage points below what was measured; low and high end bracket the measured number.
By their numbers in this assay, from the lowest: compounds 2, 1 and 3 (each within the scatter of the next, the first and the last beyond it).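

In this assay, for the compounds shown here, the change from ethoxycarbonyl to isopropoxycarbonyl gives a number 15 percentage points higher from compound 2 to compound 3 (beyond the scatter), the only step here that can be read at all. It shows that this ester position is not silent: a single added methyl on the saturated chain carbon bound to the oxygen is enough to shift the read-out, although the step is modest and the read-out is a percentage at one concentration, not a potency. Nothing available on these compounds offers an explanation for the step.

Open, from the compounds shown here alone, is whether a tert-butyl group or a longer chain such as butyl on this ester oxygen would raise the number further, or whether it would fall again. Going by these compounds alone, with only this one pair, it is also open whether the same change would give a similar step with other groups on the shared core.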